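The source may hold more compounds than are shown below. What is called first, only, known or untested is meant among the compounds shown, and "the series" means these compounds.

The series shares one core, to which a bicyclic aromatic group is attached on an aromatic carbon of the chloropyridine ring. Compound 1 `Nc1nc2ccc(-c3cnc(Cl)c(NS(=O)(=O)c4ccc(F)cc4)c3)cc2s1` is measured in an assay on U-87MG ATCC cells for inhibition of RAC-alpha serine/threonine-protein kinase (Homo sapiens), read by AlphaScreen, with a stated time of 2 h (a higher number here means a weaker inhibitor, a lower number a stronger inhibitor), at 44 nM. Compound 2 `O=S(=O)(Nc1cc(-c2ccc3nc[nH]c3c2)cnc1Cl)c1ccc(F)cc1` returns only a limit in this assay, namely > 12000 nM. Compound 3 `O=S(=O)(Nc1cc(-c2ccc3sncc3c2)cnc1Cl)c1ccc(F)cc1` likewise returns only a limit in this assay, namely > 12000 nM. The step that the two limits leave unreadable from compound 2 to compound 3 therefore cannot be read, because the limit of > 12000 nM in this assay, at which 2 of the 3 values shown sit, caps both of its values. Going by the values given here, compound 3 thus stands at the limit of this assay, without a number of its own, and compound 1 remains the only compound in the set with a measured value.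

Compound 4 `O=S(=O)(Nc1cc(-c2ccc3nccn3n2)cnc1Cl)c1ccc(F)cc1` differs from compound 3 by a group of 9 heavy atoms (6 carbon, 3 nitrogen; one five-membered aromatic ring with 2 hetero atoms, one six-membered aromatic ring with 2 hetero atoms) in place of a group of 9 heavy atoms (7 carbon, 1 nitrogen, 1 sulfur; one five-membered aromatic ring with 2 hetero atoms, one six-membered aromatic ring of carbon only), on an aromatic carbon. Among the compounds with values here, only one measured step bears on this change, a step that the two limits leave unreadable from compound 2 to compound 3, a swap of the same bicyclic group, and its size is unreadable. Both bicyclic groups other than that of compound 1 left the value at the limit, so no step beyond the scatter is expected in this assay for a step that the limit leaves unreadable from compound 3 to compound 4. Compound 4 is therefore expected to sit around 15000 nM, within 4000 nM to 50000 nM, with a high chance that only a limit is reported.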

Compound 4, half-maximal inhibitory concentration: 50 nM
The estimate for compound 4 lay 300-fold (2.48 log units) above the measured number, outside the stated range (below it).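

The change gives an at least 240-fold lower number from compound 3 to compound 4 (2.38 log units; beyond the scatter), and it gives an at least 240-fold lower number from compound 2 to compound 4 (2.38 log units; beyond the scatter). At this aromatic carbon, para to a chloro group, the choice of bicyclic group can therefore separate a compound held at a limit from one with a measured number. In this assay compound 4 gives 50 nM, which shows that a measured number here is not confined to the group of compound 1. Compound 2 and compound 3 go against any rule that a bicyclic group alone is enough. Compound 2 and compound 3 each carry only a limit, so the step between them cannot be read: the limit of > 12000 nM in this assay, at which 2 of the 4 values shown sit.

The entering group differs from the leaving one in both its atoms and its six-membered ring, and the compounds shown do not tell which of these differences carries the step, nor why it occurs. Also open, on these data alone, is whether a methoxy group or a nitrile on the entering bicyclic group, or either one in place of the chloro group, would keep a number of this kind.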